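From compound 3 to compound 4: one substituent exchanged

A few compounds are considered here, and "the series" means these few. Any claim that something is new, unique, unknown or untested is made for them only; others in the source may bear on it.

In a physicochemical assay for acid dissociation, compound 1 (`COc1ccc(-c2ccc3c(NCCCNCc4cccc(OC)c4O)ccnc3c2)cc1`) gives 9.47 and compound 2 (`COc1ccccc1Oc1ccc2c(NCCCNCc3cccc(OC)c3O)ccnc2c1`) gives 9.28 while compound 3 (`COc1cccc(CNCCCNc2ccnc3cc(-c4ccc(C(F)(F)F)cc4)ccc23)c1O`) gives 9.47 and so stands level with compound 1. Compound 4 (`COc1cccc(CNCCCNc2ccnc3cc(Cc4ccc(F)cc4Cl)ccc23)c1O`) differs from compound 3 in one place, with 2-chloro-4-fluorobenzyl in place of 4-(trifluoromethyl)phenyl on an aromatic carbon. For the measured compounds named here, three measured steps bear on this, each an exchange on an aromatic carbon: a number 0.19 log units lower from compound 1 to compound 2 (within the scatter) and a number 0.19 log units higher from compound 2 to compound 3 (within the scatter) and lastly no change at the digits printed from compound 1 to compound 3 (within the scatter) with all of them within the scatter. Going by the values given here, no measured compound carries the incoming group, so this is an inference from those steps alone. No step beyond the scatter is therefore expected in this assay here. The expected step is a number 0.07 log units lower from compound 3 to compound 4 (within the scatter) and would stay within the scatter. Compound 4 is estimated at 9.4 (expected range 9.1 to 9.7).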

Compound 4, acid dissociation constant: 9.47
Beside the measured number, compound 4's estimate is 0.07 log units below it; low and high end bracket the measured number.
By their numbers in this assay, from the lowest: compounds 2, 1, 3 and 4 (each within the scatter of the next).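

In this assay the 2-chloro-4-fluorobenzyl group gives no change at the digits printed from compound 3 to compound 4 (within the scatter) and no change at the digits printed from compound 1 to compound 4 (within the scatter) and also a number 0.19 log units higher from compound 2 to compound 4 (within the scatter) at this aromatic carbon. A benzyl group carrying chlorine and fluorine thus joins 4-methoxyphenyl, 2-methoxyphenoxy and 4-(trifluoromethyl)phenyl with no step beyond the scatter, so all four substituents shown leave the number in place. Nothing shown accounts for this. Going by these compounds, whether an amine or a carboxylic acid on this carbon would bring a step beyond the scatter stays open. So does the effect of a longer chain there.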